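This account rests on a few compounds, and the source may have more. Where it says the series, first, only, none or still open, it means among the compounds named here.

Of the compounds shown here, three built on one shared core have been tested in a functional assay on the whole organism (strain Wistar) for inhibition, with Rattus norvegicus as the target, read by paw edema, with stated times of 30 min and 3 h, at a dose of 20 mg/kg; on this read-out lower numbers stand for less inhibition and higher numbers for more inhibition at the one dose given (going by the name of the read-out). Compound 1 `CCOC(=O)C1=C(C)NC(C)=C(C(=O)OCC)C1c1ccc(OCC(=O)Nc2nc3ccccc3s2)cc1` gives 65.9%. Compound 2 `CCOC(=O)C1=C(C)NC(C)=C(C(=O)OCC)C1c1ccc(OCC(=O)NNC(=O)c2ccc(C)cc2)cc1` gives 47.3%. Compound 3 `CCOC(=O)C1=C(C)NC(C)=C(C(=O)OCC)C1c1ccc(OCc2nnc(S)o2)cc1` gives 61.1%, the second highest of the three numbers; the step of a number 4.8 percentage points lower from compound 1 to compound 3 (within the scatter) stays within the scatter, while its gap to compound 2 lies beyond the scatter.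

Compound 4 `CCOC(=O)C1=C(C)NC(C)=C(C(=O)OCC)C1c1ccc(OCC(=O)n2nc(C)cc2C)cc1` has not yet been measured. Its change from compound 3 is (3,5-dimethyl-1H-pyrazol-1-yl)carbonyl in place of 5-sulfanyl-1,3,4-oxadiazol-2-yl on a saturated chain carbon bound to an oxygen on an aromatic ring. Within the data shown here, no measured step covers exactly this exchange. The two steps that come closest both alter what hangs from the same chain: a number 4.8 percentage points lower from compound 1 to compound 3 (within the scatter) replaced the whole end of the chain without moving the number beyond the scatter, while a number 18.6 percentage points lower from compound 1 to compound 2 (beyond the scatter) replaced only the group on the amide-type nitrogen and cost a modest amount. A step of similar or smaller size, or none beyond the scatter, is therefore expected in this assay, if anything downward. Compound 4 is expected to give 55%, between 40% and 68%, which means an estimated step of a number 6.1 percentage points lower from compound 3 to compound 4 (within the scatter).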

Compound 4, a percentage reported as inhibition, in the whole organism at one dose (the size of the read-out at that dose, not a potency): 48.5%
Estimate against measurement, compound 4: 6.5 percentage points above; the range from low to high includes it.
By their numbers in this assay, from the lowest: compounds 2 and 4 (each within the scatter of the next); then compounds 3 and 1 (each within the scatter of the next).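

In this assay, putting (3,5-dimethyl-1H-pyrazol-1-yl)carbonyl in place of 5-sulfanyl-1,3,4-oxadiazol-2-yl gives a number 12.6 percentage points lower from compound 3 to compound 4 (beyond the scatter) and shows that the chain end cannot be exchanged freely, even though compound 1 and compound 3 stayed within the scatter of each other. On the carbonyl carbon, 3,5-dimethyl-1H-pyrazol-1-yl in place of (1,3-benzothiazol-2-yl)amino gives a number 17.4 percentage points lower from compound 1 to compound 4 (beyond the scatter) whereas in place of (((4-methylphenyl)carbonyl)amino)amino it gives a number 1.2 percentage points higher from compound 2 to compound 4 (within the scatter) and so the loss seen against compound 1 is shared by two quite different groups on that carbon. Nothing available here explains why these exchanges act as they do.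

The compounds shown leave open what a simple amine or a carboxylic acid at the end of the chain would give. They also leave open what a pyrazole ring without its two methyl groups would give, and how any of these compounds behaves at other doses.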